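The compounds below may be only part of what the source reports. "The series", "measured", "known", "first", "only" and "open" are said of these compounds alone.

Measured compounds:
- compound 1, `CN(c1ccc(OCCCC(=O)NO)cc1)c1ncnc2ccccc12`: 34 nM
- compound 2, `COc1ccc(N(C)c2nc(C)nc3ccccc23)cc1OCC(=O)NO`: > 1000 nM
- compound 3, `COc1ccc(N(C)c2nc(C)nc3ccccc23)cc1OCCCCC(=O)NO`: 111 nM

In an assay on isolated protein for inhibition of protein deacetylase HDAC6 (Homo sapiens), read by fluorescence, with a stated time of 1 h (a lower number here means a stronger inhibitor, a higher number a weaker inhibitor), compound 1 gives 34 nM. Compound 2 gives only a limit of the assay, > 1000 nM. Compound 3 gives 111 nM, which is the highest of the two actual numbers, with compound 1 nearest at a lower value. Within the data shown here, the one measured step, an at least 9.0-fold lower number from compound 2 to compound 3 (0.95 log units; beyond the scatter), shows that lengthening the chain between the ring oxygen and the hydroxamic acid changed the number well beyond the scatter, although the limit for compound 2 leaves the true size of that step open (the limit of > 1000 nM in this assay, at which 1 of the 3 values shown sits).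

Compound 4, `COc1ccc(N(C)c2nc(C)nc3ccccc23)cc1OCCCCCC(=O)NO`, carries the same change one bond further: (hydroxycarbamoyl)methyl in place of hydroxycarbamoyl on a saturated chain carbon, four bonds along the chain from an oxygen on an aromatic ring. That measured step bears on it only loosely, since it moved from a limit to a number. A smaller, perhaps insignificant effect is expected here, so compound 4 is estimated at 100 nM, between 40 nM and 300 nM, meaning an expected step of a 1.1-fold lower number from compound 3 to compound 4 (0.05 log units; within the scatter).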

Compound 4, half-maximal inhibitory concentration: 23 nM
For compound 4 the middle estimate is 4.3-fold (0.64 log units) above the measured one; measured number below the stated range.
By their numbers in this assay, from the lowest: compounds 4 and 1 (each within the scatter of the next); then compound 3. At a limit, above all of these: compound 2.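

Lengthening the chain still counts at this position: (hydroxycarbamoyl)methyl in place of hydroxycarbamoyl, four bonds along the chain from the oxygen on the aromatic ring, gives a 4.8-fold lower number from compound 3 to compound 4 (0.68 log units; beyond the scatter). So the number in this assay had not stopped falling at compound 3, and unlike the earlier step, this one runs between two real numbers, so its size can be read directly. The full change to 4-(hydroxycarbamoyl)butyl gives an at least 43-fold lower number from compound 2 to compound 4 (1.63 log units; beyond the scatter), but this step starts from a limit, so its true size stays open: the limit of > 1000 nM in this assay, at which 1 of the 4 values shown sits.

The compounds shown do not tell whether a still longer chain would lower the number further or raise it again. They also leave open whether a carboxylic acid in place of the hydroxycarbamoyl end would keep this trend along the chain.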